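The source may report more compounds than this note shows. Statements on the series, on what has been measured and on what is new or still open speak of the compounds shown alone.

Values in a functional assay on HeLa cells (Homo sapiens) for cytotoxicity, read by MTT assay (a higher number here means a weaker inhibitor, a lower number a stronger inhibitor), each one a limit of the assay:

- compound 1 `COc1cc(CCCCC(C)(C)O)oc(=O)c1C`: > 200000 nM
- compound 2 `CC(=O)C(C)CCCCc1cc(O)c(C)c(=O)o1`: > 200000 nM
- compound 3 `Cc1c(O)cc(CCCC(C)C)oc1=O`: > 200000 nM

Compound 3 has no numeric reading, only the limit > 200000 nM. Going by the values given here, it stands level with the other two compounds, so the series so far offers no ranking in this assay. The evidence amounts to the limit of > 200000 nM in this assay, at which 3 of the 3 values shown sit.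

Next is compound 4 `Cc1c(O)cc(CCCCC(C)(C)O)oc1=O`, not yet measured. Its difference from compound 3 is 2-hydroxy-2-methylpropyl in place of isopropyl on a saturated chain carbon, three bonds along the chain from an aromatic carbon.

Among the compounds with values here, the one measured step touching this part of the chain is a step that the two limits leave unreadable from compound 2 to compound 3, so it supplies no size to carry over. Compound 1 also carries 2-hydroxy-2-methylpropyl, on the core of compound 1, and its reading is the limit > 200000 nM. Within the data shown here, no measured compound has yet given a numeric reading in this assay, so no movement in either direction is expected beyond the scatter, and another limit reading is the likeliest outcome.

The expected change is a number no higher from compound 3 to compound 4 (the limit leaves the size open), which is estimated to be no real shift. For compound 4 the estimated value is 200000 nM, with an expected range of 100000 nM to 400000 nM.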

Compound 4, half-maximal inhibitory concentration: > 200000 nM
Compound 4: no number, only a limit; the forecaster's own chance of this, stated with the estimate: 85%; the middle value lies on the limit itself.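

In this assay compound 4 gives > 200000 nM, a limit of the assay and not a number. Going by these compounds alone, compound 1, compound 2 and compound 3 also stand at limits, so no step to compound 4 can be read. The compounds shown leave open whether any of these structural changes shifts the reading at all.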